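Alkoxy in place of ethylsulfanyl on the shared core

The source may report more compounds than this note shows. Statements on the series, on what has been measured and on what is new or still open speak of the compounds shown alone.

Measured so far in a functional assay on the whole organism for activation, with Mus musculus as the target; on this read-out lower numbers stand for an effect already at smaller amounts and higher numbers for an effect only at larger amounts of compound:
compound 1, `CCSc1nc(N)c2nc(O)n(Cc3ccccc3)c2n1`: 0.1 mg/kg
compound 2, `CCOc1nc(N)c2nc(O)n(Cc3ccccc3)c2n1`: 0.3 mg/kg
compound 3, `CCCCCOc1nc(N)c2nc(O)n(Cc3ccccc3)c2n1`: 0.3 mg/kg

Compound 1 holds the lowest number of the three in this assay. The step to compound 2 is a 3.0-fold higher number from compound 1 to compound 2 (0.48 log units; beyond the scatter), and the step to compound 3 is a 3.0-fold higher number from compound 1 to compound 3 (0.48 log units; beyond the scatter). Between the two alkoxy compounds the step is no change at the digits printed from compound 2 to compound 3 (within the scatter), so the length of the alkoxy chain does not show in the numbers from compound 2 to compound 3.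

Compound 4, `COc1nc(N)c2nc(O)n(Cc3ccccc3)c2n1`, is not yet measured. Against compound 1 the change is methoxy in place of ethylsulfanyl on an aromatic carbon. The two steps that bear on it are those from compound 1 to the alkoxy compounds, both of the same modest size and direction, and the step from compound 2 to compound 3 gives no sign that a shorter alkoxy chain would behave differently. The expectation for compound 4 in this assay is therefore a step of the same kind, a 3.0-fold higher number from compound 1 to compound 4 (0.48 log units; beyond the scatter), a higher number than compound 1.

Compound 4 is thus estimated at 0.3 mg/kg, with a range from 0.1 mg/kg to 1 mg/kg.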

Compound 4, minimum effective dose: > 1 mg/kg
Compound 4 gave a limit, no number; the forecaster's own chance of this, stated with the estimate: 5%; at least 3.3-fold (0.52 log units) between middle value and limit.
By their numbers in this assay, from the lowest: compound 1; then compounds 2 and 3 (each within the scatter of the next). At a limit, above all of these: compound 4.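

In this assay, compound 4 stands at a limit of the read-out and not at a number: the limit of > 1 mg/kg in this assay, at which 1 of the 4 values shown sits.

The flat reading across the alkoxy chain therefore holds only for compounds 2 and 3, and compound 4 goes against it, with an at least 3.3-fold higher number from compound 2 to compound 4 (0.52 log units; beyond the scatter) and an at least 3.3-fold higher number from compound 3 to compound 4 (0.52 log units; beyond the scatter), both beyond the scatter, so that at this position on the shared core the shortest alkoxy group separates from the ethoxy and pentyloxy groups. Exchanging ethylsulfanyl for methoxy also costs more than either longer alkoxy exchange, at an at least 10-fold higher number from compound 1 to compound 4 (1.00 log units; beyond the scatter), so the step away from ethylsulfanyl is no longer of one size across the alkoxy compounds.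

Going by these compounds alone, the true size of these steps stays unknown, as does the chain length between methoxy and ethoxy at which the change sets in, since a limit gives only one side of a value. Methylsulfanyl and pentylsulfanyl would show whether the sulfur-linked series follows the same dependence on chain length, and an amine at this position would show whether the linking atom can go beyond oxygen and sulfur.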